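Aryl amide variation on the shared core: bromo to fluoro

This account rests on a few compounds, and the source may have more. Where it says the series, first, only, none or still open, it means among the compounds named here.

Measured compounds in an assay on isolated protein for inhibition of aldehyde dehydrogenase 1A1 (Homo sapiens), read by spectrophotometry, tested at 10 uM; a higher number here means more inhibition at the concentration tested (going by the name of the read-out), a lower number less inhibition:
compound 1 `Cc1cccc(Cn2c(CN3CCN(C(=O)c4ccc(C(C)C)cc4)CC3)nc3ccccc32)c1`: 67.6%
compound 2 `Cc1cccc(Cn2c(CN3CCN(C(=O)C4CCCC4)CC3)nc3ccccc32)c1`: 67.5%
compound 3 `Cc1cccc(Cn2c(CN3CCN(C(=O)c4ccc(Br)cc4)CC3)nc3ccccc32)c1`: 25.8%

Compound 3 stands lowest of the three numbers in this assay, with both other compounds well above it: a number 41.8 percentage points lower from compound 1 to compound 3 (beyond the scatter) and a number 41.7 percentage points lower from compound 2 to compound 3 (beyond the scatter). Compounds 1 and 2 sit together, a number 0.1 percentage points lower from compound 1 to compound 2 (within the scatter), so the number in this assay is level whether the 4-isopropylphenyl or the cyclopentyl group stands on the carbonyl carbon, while with the 4-bromophenyl group the number is sharply lower.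

Compound 4 `Cc1cccc(Cn2c(CN3CCN(C(=O)c4ccc(F)cc4)CC3)nc3ccccc32)c1` differs from compound 3 in one place: fluoro in place of bromo on an aromatic carbon. Going by the values given here, two measured steps bear on this position: the large drop from compound 1 to compound 3 (bromo in place of isopropyl on the aromatic carbon) and the equally large drop from compound 2 to compound 3. Among the compounds with values here, no measured step shows a fluoro group on this ring, so whether the loss seen with bromo carries over to fluoro cannot be read from the data. A move back toward the level of compounds 1 and 2 is possible but uncertain; a step upward of moderate size in this assay is expected, a number 14.2 percentage points higher from compound 3 to compound 4 (beyond the scatter). Compound 4 is therefore estimated at 40%, with a range from 15% to 70%.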

Compound 4, a percentage reported as inhibition, at one concentration (the size of the read-out at that concentration, not a potency): 27.1%
Beside the measured number, compound 4's estimate is 12.9 percentage points above it; measured number inside the range.
By their numbers in this assay, from the lowest: compounds 3 and 4 (each within the scatter of the next); then compounds 2 and 1 (each within the scatter of the next).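

In this assay, the fluoro and bromo compounds stand level, with a number 1.3 percentage points higher from compound 3 to compound 4 (within the scatter), so at this aromatic carbon, para to a large group, the low number is not particular to bromo. The 4-fluorophenyl group also stays well apart from the two higher compounds, with a number 40.4 percentage points lower from compound 2 to compound 4 (beyond the scatter) for its change from cyclopentyl on the carbonyl carbon and a number 40.5 percentage points lower from compound 1 to compound 4 (beyond the scatter) for fluoro in place of isopropyl, both large steps like those already seen with bromo; across these four compounds, both halogens go with the low level, while the isopropyl and cyclopentyl compounds hold the high level. No supporting information is available to explain why the two halogen compounds stand level or why they differ from the other two.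

Still open, on these data alone, is whether a chloro group would fall in with the two halogens, and whether a methyl, tert-butyl, methoxy or dimethylamino group at this same aromatic carbon would stay with the low level or reach the high one. As far as these compounds go, it is also open whether the level seen with cyclopentyl on the carbonyl carbon extends to a cyclohexyl or cyclobutyl group.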